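Aryl for alkyl on the amine nitrogen

The compounds below may be only part of what the source reports. "The series", "measured", "known", "first", "only" and "open" are said of these compounds alone.

Compound 1 `CCCOc1ccc(C(=O)Nc2cccc(Cl)n2)cc1`: in an in vitro assay on HEK-tsA201 cells for antagonist activity at Neuronal acetylcholine receptor; alpha3/beta4 (Homo sapiens), read by fluorescence and calcium flux (on this read-out higher numbers stand for weaker inhibition and lower numbers for stronger inhibition), compound 1 reaches only the assay limit of > 100000 nM.
Compound 2 `CCCNc1cccc(NC(=O)c2ccc(OCCC)cc2)n1`: in this assay compound 2 gives 12600 nM.

For the measured compounds named here, compound 2 holds the only measured number in this assay; the other value is a limit. Going by the values given here, the single measured step, an at least 7.9-fold lower number from compound 1 to compound 2 (0.89 log units; beyond the scatter), starts at a limit (the limit of > 100000 nM in this assay, at which 1 of the 2 values shown sits), so its true size is open. Compound 3 `CCCOc1ccc(C(=O)Nc2cccc(Nc3ccccc3F)n2)cc1` differs from compound 2 by 2-fluorophenyl in place of propyl on a nitrogen on an aromatic ring. Among the compounds with values here, no measured step exchanges an alkyl for an aryl group on this nitrogen; the step from compound 1 to compound 2 shows only that propylamino in place of chloro brings the number under the limit, and tells nothing about a 2-fluorophenyl group there. Compound 3 is therefore expected to stay near compound 2, with an estimated step of a 1.6-fold lower number from compound 2 to compound 3 (0.20 log units; within the scatter). The estimate for compound 3 is 8000 nM, expected between 2000 nM and 40000 nM.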

Compound 3, half-maximal inhibitory concentration: > 100000 nM
Compound 3 gave a limit, no number; the forecaster's own chance of this, stated with the estimate: 15%; middle value at least 12-fold (1.09 log units) from the limit.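

Exchanging propyl for 2-fluorophenyl on this nitrogen gives an at least 7.9-fold higher number from compound 2 to compound 3 (0.89 log units; beyond the scatter) in this assay. An amino nitrogen in place of chloro is thus not enough on its own to bring the number under the limit, and the group carried on that nitrogen decides whether a number appears at all. The true size of this step is open, and the step from compound 1 to compound 3 joins two limits and cannot be read: the limit of > 100000 nM in this assay, at which 2 of the 3 values shown sit.

The compounds shown leave open whether the aryl ring itself or its fluorine goes with this result, a question that plain phenylamino would separate. They also leave open how the number responds to other alkyl groups on this nitrogen, such as butyl or cyclopropylmethyl.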